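A few compounds are considered here, and "the series" means these few. Any claim that something is new, unique, unknown or untested is made for them only; others in the source may bear on it.

Three hydrazone analogues sharing one core have been measured in a functional assay on PC-3 cells (Homo sapiens) for inhibition; a higher number here means a weaker inhibitor, a lower number a stronger inhibitor. Compound 1, `Cc1c(C(=O)N/N=C\c2ccccc2C(F)(F)F)oc2cccc(O)c12`, gives 26200 nM. Compound 2, `Cc1c(C(=O)N/N=C\c2cccc(O)c2)oc2cccc(O)c12`, gives 17600 nM. Compound 3, `Cc1c(C(=O)N/N=C\c2cc(Cl)cc(Cl)c2O)oc2cccc(O)c12`, gives 9590 nM. On these numbers compound 2 lies within the usual scatter of both its neighbours: its separation from compound 1 and its separation from compound 3 are each too small to call a real difference, so no ranking of compound 2 against either can be drawn from this set.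

The next compound to be read in this assay is compound 4, `Cc1c(C(=O)N/N=C\c2ccc(F)cc2)oc2cccc(O)c12`. It differs from compound 2 in one place: 4-fluorophenyl in place of 3-hydroxyphenyl on a carbon with a double bond to nitrogen. Going by the values given here, the hydrogen-bond donor and acceptor carried by the leaving group are not present in the entering group, and no measured pair isolates that swap, so there is no directly comparable step to lean on.

With the three measured values all within a narrow band, the step from compound 2 to compound 4 is expected to be small, most likely no larger than the scatter and, if anything, toward a weaker inhibitor, giving a 1.3-fold higher number from compound 2 to compound 4 (0.12 log units; within the scatter). Compound 4 is therefore estimated at 23000 nM in this assay, with a plausible range from 9000 nM to 60000 nM.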

Compound 4, half-maximal inhibitory concentration: >= 40000 nM
Compound 4 was reported as a limit; the forecaster's own chance of this, stated with the estimate: 20%; middle value at least 1.7-fold (0.24 log units) away from the limit.
By their numbers in this assay, from the lowest: compounds 3, 2 and 1 (each within the scatter of the next, the first and the last beyond it). At a limit, above all of these: compound 4.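

Compound 4 gives >= 40000 nM in this assay, and this is a limit of the assay, not a number. Even so, 4-fluorophenyl in place of 3-hydroxyphenyl on a carbon with a double bond to nitrogen gives an at least 2.2-fold higher number from compound 2 to compound 4 (0.35 log units; beyond the scatter), so this change produces a separation that compound 2 did not show against either of its earlier neighbours. The position therefore does not tolerate every aryl group equally in this assay, and the loss of the hydrogen-bond donor and acceptor of the leaving group goes with a weaker inhibitor here, although this single pair cannot show that those features are responsible.

On these data alone, the true size of the step stays open, since one end of it is a limit, and the swap changes both the substituent and where it sits on the ring, so the two cannot be told apart. A 3-fluorophenyl or a 4-hydroxyphenyl group would separate them, and a 3-aminophenyl or 3-carboxyphenyl group would show whether other groups on this ring keep the value of compound 2.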